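Pyrrolidin-1-yl to piperidin-1-yl on the chloro compound

The compounds below may be only part of what the source reports. "The series", "measured", "known", "first", "only" and "open" are said of these compounds alone.

Measured so far in a functional assay on LOX IMVI cells (Homo sapiens) for inhibition, read by sulforhodamine B assay, with a stated time of 48 h; on this read-out lower numbers stand for stronger inhibition of growth and higher numbers for weaker inhibition of growth
- compound 1 `COc1cc2nc(-c3ccc(C(F)(F)F)cc3)cc(OCCCN3CCCC3)c2cc1OC`: 116 nM
- compound 2 `COc1cc2nc(-c3ccc(Cl)cc3)cc(OCCCN3CCCC3)c2cc1OC`: 191 nM
- compound 3 `COc1cc2nc(-c3ccc(C(F)(F)F)cc3)cc(OCCCN3CCC(O)CC3)c2cc1OC`: 190 nM

Compound 2 at 191 nM lies within the scatter of compound 1 and compound 3, so the three values show no order. Compound 4 `COc1cc2nc(-c3ccc(Cl)cc3)cc(OCCCN3CCCCC3)c2cc1OC` carries piperidin-1-yl in place of pyrrolidin-1-yl on the propyl chain piperidin-1-yl in place of pyrrolidin-1-yl on a saturated chain carbon, three bonds along the chain from an oxygen on an aromatic ring and has not been measured. The nearest measured change is a 1.6-fold higher number from compound 1 to compound 3 (0.21 log units; within the scatter) with 4-hydroxypiperidin-1-yl entering at the same place. The chloro change, a 1.6-fold higher number from compound 1 to compound 2 (0.22 log units; within the scatter), bears on it only indirectly. Among the measured compounds shown here, no measured compound carries piperidin-1-yl itself. In this assay the expected change is a 1.0-fold higher number from compound 2 to compound 4 (0.02 log units; within the scatter) and so none beyond the scatter. The estimated value for compound 4 is 200 nM with 100 nM to 400 nM as the expected range.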

Compound 4, concentration for 50% growth inhibition: 189 nM
Compound 4: middle estimate off by 1.1-fold (0.02 log units), on the high side; the measured number falls inside the stated range.
By their numbers in this assay, from the lowest: compounds 1, 4, 3 and 2 (each within the scatter of the next).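

In this assay, piperidin-1-yl in place of pyrrolidin-1-yl gives a 1.0-fold lower number from compound 2 to compound 4 (0.00 log units; within the scatter). Unlike the change to 4-hydroxypiperidin-1-yl, this step alters the ring alone, and on the chloro compounds the five-membered and six-membered rings cannot be told apart at this place. No supporting data are available to account for this result.

Still open, from the compounds shown here alone, is whether the same holds with trifluoromethyl on the aromatic ring. Also open, going by these compounds, is what morpholin-4-yl, dimethylamino or a longer chain would give at this place.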